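Pyridin-3-yl to pyridin-4-yl: a small step expected

The compounds below may be only part of what the source reports. "The series", "measured", "known", "first", "only" and "open" are said of these compounds alone.

Compound 1 `Nc1nc2[nH]c(CCSCCC(=O)NCc3ccccn3)cc2c(=O)[nH]1` gives 11900 nM
Compound 2 `Nc1nc2[nH]c(CCSCCC(=O)N[C@@H](CCC(=O)O)C(=O)O)cc2c(=O)[nH]1` gives 387 nM
Compound 3 `Nc1nc2[nH]c(CCSCC(=O)NCc3cccnc3)cc2c(=O)[nH]1` gives 25300 nM

In a functional assay on SW-620 cells (Homo sapiens) for antiproliferative activity, read by MTT assay, with a stated time of 72 h, in the presence of a further agent that is not named here (a higher number here means a weaker inhibitor, a lower number a stronger inhibitor), compound 3 reads 25300 nM and holds the highest of the three numbers, with compound 1 at 11900 nM and compound 2 at 387 nM both lower.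

Compound 4 `Nc1nc2[nH]c(CCSCC(=O)NCc3ccncc3)cc2c(=O)[nH]1` differs from compound 3 in one place, with pyridin-4-yl in place of pyridin-3-yl on a saturated chain carbon bound to an amide-type nitrogen.

Within the data shown here, only one step between measured compounds is available. The step of a 31-fold lower number from compound 1 to compound 2 (1.49 log units; beyond the scatter) is large and beyond the scatter, and it puts 1,3-dicarboxypropyl in place of (pyridin-2-yl)methyl on an amide-type nitrogen. That exchange removes the pyridinyl group altogether, so it bears only weakly on the present change. Among the measured compounds shown here, no measured step exchanges one pyridinyl group for another, and the data offer no direct guide to its size.

The expectation therefore rests on compound 3 at 25300 nM as the starting point. The estimate is a 1.2-fold lower number from compound 3 to compound 4 (0.06 log units; within the scatter) and so no step beyond the scatter is expected in this assay in either direction. Compound 4 is estimated at 22000 nM with an expected range from 9000 nM to 50000 nM in this measurement.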

Compound 4, half-maximal inhibitory concentration: 22700 nM
Compound 4: middle estimate off by 1.0-fold (0.01 log units), on the low side; the range from low to high includes it.
By their numbers in this assay, from the lowest: compound 2; then compounds 1, 4 and 3 (each within the scatter of the next, the first and the last beyond it).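

In this assay, pyridin-4-yl in place of pyridin-3-yl on a saturated chain carbon bound to an amide-type nitrogen gives a 1.1-fold lower number from compound 3 to compound 4 (0.05 log units; within the scatter), so this exchange does not separate the two compounds. Among these compounds, the only earlier step, a 31-fold lower number from compound 1 to compound 2 (1.49 log units; beyond the scatter), removed the pyridinyl group altogether and could not show what a change within that group does; here, with the pyridinyl group kept and only its attachment changed, the read-out stays within the scatter at this place. The compounds shown offer no measurement that could explain this outcome.

The compounds shown leave open whether this insensitivity extends beyond these two pyridinyl groups, for instance to a plain phenyl ring or to a piperidin-4-yl group at the same place. They also leave open whether a carboxylic acid on this chain, in place of the pyridinyl group, would bring a step as large as the one seen on going to the 1,3-dicarboxypropyl group, or whether a pyridin-2-yl group would match compound 3 and compound 4 on their own chain.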